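Working notes: adding a methyl to compound 2

This account rests on a few compounds, and the source may have more. Where it says the series, first, only, none or still open, it means among the compounds named here.

Measured in a functional assay on PC-3 cells (Homo sapiens) for inhibition, read by sulforhodamine B assay; on this read-out higher numbers stand for weaker inhibition of growth and lower numbers for stronger inhibition of growth:
Compound 1 `c1ccc(-c2ccc(-c3ccc(-c4nc5ccccc5[nH]4)cc3)cc2)cc1`: 41200 nM
Compound 2 `FC(F)(F)Oc1ccc(-c2ccc(-c3ccc(-c4nc5ccccc5[nH]4)cc3)cc2)cc1`: 100000 nM
Compound 3 `COc1ccc(-c2ccc(-c3ccc(-c4nc5ccccc5[nH]4)cc3)cc2)cc1`: 100000 nM

Compound 2 shares the highest number of the three, with no change at the digits printed from compound 2 to compound 3 (within the scatter). Compound 4 `Cc1ccc2[nH]c(-c3ccc(-c4ccc(-c5ccc(OC(F)(F)F)cc5)cc4)cc3)nc2c1` differs from compound 2 by methyl in place of hydrogen on an aromatic carbon, turning 1H-benzimidazol-2-yl into 5-methyl-1H-benzimidazol-2-yl. Among the measured compounds shown here, no measured step touches that place. For the measured compounds named here, the only guides are modest changes elsewhere, a 2.4-fold higher number from compound 1 to compound 2 (0.39 log units; beyond the scatter) and a 2.4-fold higher number from compound 1 to compound 3 (0.39 log units; beyond the scatter). In this assay, no step beyond the scatter is therefore expected, and no direction can be argued. The estimated step is a 1.3-fold lower number from compound 2 to compound 4 (0.10 log units; within the scatter). For compound 4 the expected value is 80000 nM, with an estimated range of 40000 nM to 120000 nM.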

Compound 4, concentration for 50% growth inhibition: 2010 nM
Compound 4: the middle estimate sits 40-fold (1.60 log units) above what was measured, outside the stated range (below it).
By their numbers in this assay, from the lowest: compound 4; then compound 1; then compounds 2 and 3 (each within the scatter of the next).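

The 1H-benzimidazol-2-yl group turns out to be a sensitive place in this assay: changing it to 5-methyl-1H-benzimidazol-2-yl gives a 50-fold lower number from compound 2 to compound 4 (1.70 log units; beyond the scatter), with growth inhibition much stronger. A single added methyl moves the number far more than either earlier change on the other aromatic carbon, a 2.4-fold higher number from compound 1 to compound 2 (0.39 log units; beyond the scatter) and a 2.4-fold higher number from compound 1 to compound 3 (0.39 log units; beyond the scatter). Nothing available gives a reason for this step.

Open, on these data alone, is whether the gain is specific to methyl or also appears with ethyl, chlorine or an amine on that aromatic carbon. Also open, as far as these compounds go, is whether the same methyl gives a comparable step on compound 1 or compound 3.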